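Chloro in place of methyl in compound 4

This account rests on a few compounds, and the source may have more. Where it says the series, first, only, none or still open, it means among the compounds named here.

In a functional assay on RS4-11 cells (Homo sapiens) for inhibition, read by CCK-8 assay, with a stated time of 48 h, tested at 20 uM (on this read-out lower numbers stand for less inhibition of growth and higher numbers for more inhibition of growth at the one concentration tested), compound 3 (`Cc1ccc(S(=O)(=O)Oc2ccccc2/C=C(\C#N)C(=O)Nc2nnc(Cc3ccccc3)s2)cc1`) gives 69% and stands within the usual scatter of both other measured compounds: compound 2 (`Cc1ccc(S(=O)(=O)Oc2ccccc2/C=C(\C#N)C(=O)Nc2nnc(Cc3cccc4ccccc34)s2)cc1`) gives 73% and compound 1 (`COc1ccc(Cc2nnc(NC(=O)/C(C#N)=C/c3ccccc3OS(=O)(=O)c3ccc(Cl)cc3)s2)cc1`) gives 79% on the same read-out. Compound 4 (`N#C/C(=C\c1ccccc1OS(=O)(=O)c1ccc(Cl)cc1)C(=O)Nc1nnc(Cc2ccccc2)s1`) differs from compound 3 by a single change (chloro in place of methyl on an aromatic carbon), chloro in place of methyl on an aromatic carbon, para to a large group. Within the data shown here, the only measured step in one place is a number 4 percentage points lower from compound 2 to compound 3 (within the scatter) and it exchanges naphthalen-1-yl for phenyl, not methyl for chloro, so it bears on this change only loosely. Among the measured compounds shown here, compound 1 also carries the 4-chlorophenyl group, yet no measured pair isolates this exchange, and the values of compound 1 and compound 3 lie within the scatter of each other. Expected for this change is a small step in this assay (a number 4 percentage points higher from compound 3 to compound 4 (within the scatter)), with none beyond the scatter. Compound 4 is expected at 73% (estimated range 60% to 85%).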

Compound 4, percent growth inhibition at one concentration: 73%
Beside the measured number, compound 4's estimate shows no gap at the digits printed, within the range that was stated.
By their numbers in this assay, from the lowest: compounds 3, 2, 4 and 1 (each within the scatter of the next).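

In this assay, the exchange of methyl for chloro on an aromatic carbon, para to a large group, now has a measured pair of its own, and it gives a number 4 percentage points higher from compound 3 to compound 4 (within the scatter). The 4-methylphenyl and 4-chlorophenyl groups therefore cannot be told apart on this read-out, with the rest of the molecule held the same. A second pair, with hydrogen in place of methoxy on an aromatic carbon, gives a number 6 percentage points lower from compound 1 to compound 4 (within the scatter), and no measurement shown offers an explanation for either step.

Only methyl and chloro are shown at this position, so the effect of a more different group there, such as an amine or a carboxylic acid, remains open. As far as these compounds go, whether methyl and chloro would also stay within the scatter of each other at other concentrations is equally open, since all these values come from a single concentration.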